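Dimethylamino for acetyl on a pyrazole-pyridine core

The source may report more compounds than this note shows. Statements on the series, on what has been measured and on what is new or still open speak of the compounds shown alone.

Compound 1, `COc1cc(C)cc(-c2c(-c3ccnc(-c4ccc(C(C)=O)cc4)c3)cnn2CC#N)c1`: > 100000 nM
Compound 2, `COc1cc(C)cc(-c2nn(CC#N)cc2-c2ccnc(-c3ccc(N(C)C)cc3)c2)c1`: > 100000 nM

In a functional assay on A549 cells (Homo sapiens) for inhibition, read by sulforhodamine B assay, with a stated time of 48 h (on this read-out higher numbers stand for lower toxicity in this test and lower numbers for higher toxicity in this test), compound 1 gives only > 100000 nM, which is a limit of the assay and not a number. Compound 2 likewise reaches > 100000 nM, again a limit. Among the compounds with values here, compound 1 therefore stands at the limit of > 100000 nM in this assay, at which 2 of the 2 values shown sit, and no step between measured compounds can be read off. Compound 3, `COc1cc(C)cc(-c2c(-c3ccnc(-c4ccc(N(C)C)cc4)c3)cnn2CC#N)c1`, differs from compound 1 by dimethylamino in place of acetyl on an aromatic carbon. The step from compound 1 to compound 3 is expected to stay within the scatter, as a number no higher from compound 1 to compound 3 (the limit leaves the size open), with the limit again the likely outcome. Compound 3 is thus estimated at 100000 nM, within 30000 nM to 300000 nM.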

Compound 3, concentration lethal to 50% of the cells: > 100000 nM
Compound 3: only a limit was reported; the forecaster's own chance of this, stated with the estimate: 80%; the middle value lies on the limit itself.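

No step from compound 1 to compound 3 can be read, because both results are limits and not numbers: the limit of > 100000 nM in this assay, at which 3 of the 3 values shown sit.

The compounds shown leave open whether dimethylamino in place of acetyl changes toxicity in this test at all.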